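Methyl for phenyl on the sulfonyl of compound 2

The source may report more compounds than this note shows. Statements on the series, on what has been measured and on what is new or still open speak of the compounds shown alone.

Compound 1 `CCCCc1ccc(CN(Cc2ccccc2OCC(=O)O)S(C)(=O)=O)cc1`: 3200 nM
Compound 2 `CC(C)(C)c1ccc(CN(Cc2cccc(CCC(=O)O)c2)S(=O)(=O)c2ccccc2)cc1`: 278 nM

Compound 2 holds the lower of the two numbers recorded in an assay on HEK293 cells for inhibition of prostaglandin E2 receptor EP2 subtype (Rattus norvegicus); a lower number here means a stronger inhibitor, a higher number a weaker inhibitor; compound 1 sits a good deal higher, and since the two differ in more than one place, only their two values can be compared. Compound 3 `CC(C)(C)c1ccc(CN(Cc2cccc(CCC(=O)O)c2)S(C)(=O)=O)cc1` is not yet measured. It keeps everything of compound 2 except (methyl in place of phenyl on a sulfonyl sulfur). Within the data shown here, no measured pair isolates this change, so the expectation rests on compound 2 alone. The step is expected to weaken inhibition, a 2.5-fold higher number from compound 2 to compound 3 (0.40 log units; beyond the scatter), beyond the scatter but not by a large margin. Compound 3 is thus estimated at 700 nM, within a range of 200 nM to 2500 nM.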

Compound 3, half-maximal inhibitory concentration: 379 nM
Estimate against measurement, compound 3: 1.8-fold (0.27 log units) above; the measured number falls inside the stated range.
By their numbers in this assay, from the lowest: compounds 2 and 3 (each within the scatter of the next); then compound 1.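

Putting methyl in place of phenyl on a sulfonyl sulfur gives, in this assay, a 1.4-fold higher number from compound 2 to compound 3 (0.13 log units; within the scatter), so with the rest of compound 2 kept, this position tolerates the loss of the whole six-membered aromatic ring without a change this measurement can resolve. No measured property of these compounds speaks to the reason. Still open, going by these compounds, is whether a longer chain such as butyl, or an amine, on the sulfonyl sulfur would behave like methyl and phenyl. Also open, on these data alone, is whether phenyl and methyl would match on the core of compound 1.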